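Nitrile to Methylsulfonyl: Cytotoxicity Expected to Stay at Limit

The source may report more compounds than this note shows. Statements on the series, on what has been measured and on what is new or still open speak of the compounds shown alone.

Three compounds share one core and differ only in the aryl group on an amide-type nitrogen in a ring. Compound 1, `COc1ccc([C@H]2CC(=O)N(c3cc(N)cc(N)c3)C2)cc1OC1CCCC1`, gives in a functional assay on HEK293 cells (Homo sapiens) for cytotoxicity (a higher number here means that more compound is tolerated, a lower number that less compound is tolerated), a result that is a limit of the assay, > 10000 nM. Compound 2, `COc1ccc([C@H]2CC(=O)N(c3ccc(C)c(N)c3)C2)cc1OC1CCCC1`, likewise gives only a limit in this assay, > 10000 nM. Compound 3, `COc1ccc([C@H]2CC(=O)N(c3cccc(C#N)c3)C2)cc1OC1CCCC1`, also gives a limit in this assay, > 10000 nM. Because (the limit of > 10000 nM in this assay, at which 3 of the 3 values shown sit), none of the steps among them can be read: a step that the two limits leave unreadable from compound 1 to compound 2, a step that the two limits leave unreadable from compound 1 to compound 3 and a step that the two limits leave unreadable from compound 2 to compound 3 are all unreadable in size.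

Compound 4, `COc1ccc([C@H]2CC(=O)N(c3cccc(S(C)(=O)=O)c3)C2)cc1OC1CCCC1`, differs from compound 3 in one place: methylsulfonyl in place of cyano on an aromatic carbon. Three different groups at the same place all left the measurement at the limit, so no readable step bears on this change, and no shift beyond the scatter in this assay is expected. Compound 4 is therefore expected to sit at the limit as well. The expected step that the limit leaves unreadable from compound 3 to compound 4 amounts to essentially none. The estimate for compound 4 in this assay is 15000 nM, with a range from 8000 nM to 30000 nM.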

Compound 4, half-maximal cytotoxic concentration: > 10000 nM
Compound 4 was reported as a limit; the forecaster's own chance of this, stated with the estimate: 85%; the middle value is on the limit's open side.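

No new step can be read among compound 1, compound 2, compound 3 and compound 4, because all four sit at the same assay limit: the limit of > 10000 nM in this assay, at which 4 of the 4 values shown sit.

The compounds shown leave open at what concentration any of them would harm the cells in this assay, and whether the aryl groups differ at all.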